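One Aromatic Substituent Swap, Three Flat Measurements

The compounds below may be only part of what the source reports. "The series", "measured", "known", "first", "only" and "open" are said of these compounds alone.

Compound 1 `COc1ccc(CO/N=C/c2c(C)nn(C)c2Oc2ccc(Cl)cc2)cc1`: 28.1%
Compound 2 `Cc1nn(C)c(Oc2ccc(Cl)cc2)c1/C=N/OCc1ccc(C(F)(F)F)cc1`: 27.6%
Compound 3 `Cc1nn(C)c(Oc2ccc(Cl)cc2)c1/C=N/OCc1ccc([N+](=O)[O-])cc1`: 24.6%

In a functional assay on MKN-45 cells (Homo sapiens) for antiproliferative activity, tested at 1 uM (a lower number here means less inhibition, a higher number more inhibition at the concentration tested (going by the name of the read-out)), compound 3 gives 24.6%, the lowest of the three numbers, yet its gaps to both neighbours fall within the scatter: a number 3.5 percentage points lower from compound 1 to compound 3 (within the scatter) and a number 3 percentage points lower from compound 2 to compound 3 (within the scatter). Compound 4 `COC(=O)c1ccc(CO/N=C/c2c(C)nn(C)c2Oc2ccc(Cl)cc2)cc1` differs from compound 3 by methoxycarbonyl in place of nitro on an aromatic carbon. Going by the values given here, the steps that bear on this change are the three substituent swaps on the same aromatic carbon, a number 0.5 percentage points lower from compound 1 to compound 2 (within the scatter), a number 3.5 percentage points lower from compound 1 to compound 3 (within the scatter) and a number 3 percentage points lower from compound 2 to compound 3 (within the scatter), each within the scatter. Compound 4 is therefore expected to show no step beyond the scatter, a number 1.4 percentage points higher from compound 3 to compound 4 (within the scatter), and its value in this assay is estimated at 26%, between 14% and 38%.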

Compound 4, a percentage reported as inhibition, at one concentration (the size of the read-out at that concentration, not a potency): 26.1%
Compound 4: middle estimate off by 0.1 percentage points, on the low side; the range from low to high includes it.
By their numbers in this assay, from the lowest: compounds 3, 4, 2 and 1 (each within the scatter of the next).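

In this assay, methoxycarbonyl on this aromatic carbon, para to a large group, stays within the scatter of all three earlier groups: a number 1.5 percentage points higher from compound 3 to compound 4 (within the scatter), a number 1.5 percentage points lower from compound 2 to compound 4 (within the scatter) and a number 2 percentage points lower from compound 1 to compound 4 (within the scatter). Going by these compounds alone, the swap to a fourth group, this one bearing a carbonyl, therefore still produces no step that can be read as a real change at this position. Nothing available explains this flat result. Going by these compounds, whether an amine or a carboxylic acid on this carbon would give a step beyond the scatter stays open, as does the effect of a longer chain linking this ring to the shared core.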